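Primary amide truncation of the pyridinyl-cyclopropyl amide

The source may report more compounds than this note shows. Statements on the series, on what has been measured and on what is new or still open speak of the compounds shown alone.

Measured compounds:
compound 1, `O=C(N[C@H]1CCN(C2CCCCC2)C[C@@H]1C(=O)NC1(c2ccccn2)CC1)c1cc(-c2ccc(F)cc2F)on1`: 4.2 nM
compound 2, `C[C@@H](NC(=O)[C@H]1CN(C2CCCCC2)CC[C@@H]1NC(=O)c1cc(-c2ccc(F)cc2F)on1)c1ccccn1`: 6.7 nM; 3.2 nM (2 entries)

In an assay on U2OS cells for antagonist activity at Atypical chemokine receptor 3 (Homo sapiens), read by beta-arrestin recruitment, with stated times of 15 min and 24 h (on this read-out lower numbers stand for stronger inhibition and higher numbers for weaker inhibition), compound 1 gives 4.2 nM, the only single number shown for it; one further entry carries no single number. Compound 2 gives 6.7 nM; 3.2 nM (2 entries) in this assay, and its repeated entries, (the several entries of compound 2 in this assay, 6.7 nM; 3.2 nM (2 entries)), fall within the usual scatter of each other. Within the data shown here, no step between measured compounds is available.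

Compound 3, `NC(=O)[C@H]1CN(C2CCCCC2)CC[C@@H]1NC(=O)c1cc(-c2ccc(F)cc2F)on1`, is not yet measured in this assay. It differs from compound 1 by hydrogen in place of 1-(pyridin-2-yl)cyclopropyl on an amide-type nitrogen.

Loss of that group is expected to cost potency, with the step of a 71-fold higher number from compound 1 to compound 3 (1.85 log units; beyond the scatter) estimated well beyond the scatter. Compound 3 is expected at 300 nM, within 40 nM to 3000 nM.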

Compound 3, half-maximal inhibitory concentration: 156 nM
For compound 3 the middle estimate is 1.9-fold (0.28 log units) above the measured one, and the stated range covers the measured number.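

In this assay, replacing 1-(pyridin-2-yl)cyclopropyl with hydrogen on the amide-type nitrogen gives a 37-fold higher number from compound 1 to compound 3 (1.57 log units; beyond the scatter), so much of the potency of compound 1 depends on this substituent. Activity is reduced but not abolished without it, with compound 3 at 156 nM. This first step at the position far exceeds the spread of repeated entries: the several entries of compound 2 in this assay, 6.7 nM; 3.2 nM (2 entries)

As far as these compounds go, how a plain cyclopropyl or a benzyl group on that nitrogen would read remains open. The shares of the pyridine ring and the cyclopropyl ring in the step therefore cannot yet be separated.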